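Small side chain changes on a shared core

The source may hold more compounds than are shown below. What is called first, only, known or untested is meant among the compounds shown, and "the series" means these compounds.

- Compound 1 (`CCC(=O)NCc1ccc(NC(=O)[C@H]2C[C@@H]2c2cccnc2)cc1`): > 2500 nM
- Compound 2 (`O=C(N[C@@H](CO)c1ccc(NC(=O)[C@H]2C[C@@H]2c2cccnc2)cc1)c1ccccc1`): 630 nM

In a functional assay on COR-L23 cells (Homo sapiens) for antiproliferative activity, read by CellTiter-Glo, with a stated time of 4 days (a higher number here means a weaker inhibitor, a lower number a stronger inhibitor), compound 1 reads > 2500 nM as a limit of the assay, not a number. Compound 2 gives 630 nM as a true number in this assay on the same scale. Compound 3 (`COCC(=O)N[C@@H](C)c1ccc(NC(=O)[C@H]2C[C@@H]2c2cccnc2)cc1`) differs from compound 1 in one place (a group of 8 heavy atoms (5 carbon, 1 nitrogen, 2 oxygen; no ring) in place of a group of 6 heavy atoms (4 carbon, 1 nitrogen, 1 oxygen; no ring), on an aromatic carbon). Among the measured compounds shown here, no measured step covers this change, so only a modest gain in strength is expected, an estimated at least 1.6-fold lower number from compound 1 to compound 3 (0.22 log units; that floor lies within the scatter) toward lower numbers. For the measured compounds named here, compound 2 at 630 nM shows that true numbers occur in this family, and that is the only guide. Compound 3 is expected at 1500 nM (estimated range 450 nM to 5000 nM).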

Compound 3, half-maximal inhibitory concentration: 111 nM
Compound 3: the middle estimate sits 14-fold (1.13 log units) above what was measured, and the stated range ends above it.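

In this assay, the side chain on this aromatic carbon, para to a large group, has a strong hold on the reading: swapping (propanoylamino)methyl for the larger group with a defined stereocentre gives an at least 22-fold lower number from compound 1 to compound 3 (1.35 log units; beyond the scatter). That size is only a floor, because compound 1 stands at a limit and not at a number: the limit of > 2500 nM in this assay, at which 1 of the 3 values shown sits. The change adds the stereocentre and an oxygen together, and this single step cannot divide the gain between them.

Still open, going by these compounds, is how the opposite stereocentre would read, or an amine in place of that oxygen.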